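Oxime substitution on the diaryl sulfide series

The compounds below may be only part of what the source reports. "The series", "measured", "known", "first", "only" and "open" are said of these compounds alone.

Of the compounds shown here, two have numbers so far. Compound 1 `COC1(c2cc(F)cc(Sc3ccc4c(c3)OCC/C4=N\OCC#N)c2)CCOCC1` gives 40 nM in a functional assay (blood) for inhibition, with Homo sapiens as the target; a higher number here means a weaker inhibitor, a lower number a stronger inhibitor. Compound 2 `O/N=C(/c1ccc(Sc2cc(F)cc(C3CCOCC3)c2)cc1)C(F)(F)F` gives 280 nM in this assay, the higher of the two numbers; compound 1 sits at a number lower by a margin well beyond the scatter. The two compounds differ in more than one place, so the gap between them is not tied to a single change.

The next step goes from compound 2 to compound 3 `C/C(=N\OCC(=O)O)c1ccc(Sc2cc(F)cc(C3CCOCC3)c2)cc1`. The change is at one point on the core of compound 2: a group of 8 heavy atoms (4 carbon, 1 nitrogen, 3 oxygen; no ring) in place of a group of 7 heavy atoms (2 carbon, 1 nitrogen, 1 oxygen, 3 fluorine; no ring), on an aromatic carbon. The leaving group carries three fluorine atoms and one hydrogen-bond donor; the entering group carries three oxygen atoms, one hydrogen-bond donor and a second double bond outside aromatic rings. For the measured compounds named here, no measured pair in the set covers this exact exchange, so the size of the step cannot be read from the data.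

Compound 3 is expected to give 180 nM in this assay, with a range of 50 nM to 650 nM. This estimate means a step of a 1.6-fold lower number from compound 2 to compound 3 (0.19 log units; within the scatter), a modest move toward a lower number that may not exceed the scatter.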

Compound 3, half-maximal inhibitory concentration: 740 nM
The estimate for compound 3 lay 4.1-fold (0.61 log units) below the measured number; measured number outside the range, above it.
By their numbers in this assay, from the lowest: compound 1; then compound 2; then compound 3.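

The position on the aromatic carbon para to a large group is sensitive to what it carries: in this assay the group of 8 heavy atoms in place of the group of 7 heavy atoms gives a 2.6-fold higher number from compound 2 to compound 3 (0.42 log units; beyond the scatter), a weaker inhibitor by a margin beyond the scatter. On this core, then, the oxime ether ending in a carboxylic acid does not improve on the trifluoromethyl oxime with its free hydroxyl, even though the count of hydrogen-bond donors stays the same. Nothing available bears on the reason for this step.

The exchange alters the trifluoromethyl on the oxime carbon and the substituent on the oxime oxygen together, so these two compounds cannot show which of the two changes carries the step. Open questions are how a methyl oxime with a free hydroxyl would read, which would separate the two changes, and whether a methyl ester or a primary amide at the end of the chain would read differently from the carboxylic acid.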